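This account rests on a few compounds, and the source may have more. Where it says the series, first, only, none or still open, it means among the compounds named here.

Compound 1 `CCn1cc(-c2nc3ccccc3[nH]2)c(=O)c2cc(F)c(N3CCNCC3)cc21` gives 27400 nM in a functional assay on Bel-7402 cells (Homo sapiens) for cytotoxicity, read by MTT assay, with a stated time of 48 h (on this read-out higher numbers stand for weaker inhibition and lower numbers for stronger inhibition), while compound 2 `CCn1cc(-c2nc3ccc(Cl)cc3[nH]2)c(=O)c2cc(F)c(N3CCNCC3)cc21` gives 2800 nM, the lowest of the two numbers seen. Among the measured compounds shown here, the only measured step is a 9.8-fold lower number from compound 1 to compound 2 (0.99 log units; beyond the scatter). Compound 3 `CCn1cc(-c2nc3ccc([N+](=O)[O-])cc3[nH]2)c(=O)c2cc(F)c(N3CCNCC3)cc21` differs from compound 2 by nitro in place of chloro on an aromatic carbon. Because a 9.8-fold lower number from compound 1 to compound 2 (0.99 log units; beyond the scatter) concerns adding a group where hydrogen stood, not swapping one group for another, it gives little guidance, and compound 3 is expected to show a 1.4-fold lower number from compound 2 to compound 3 (0.15 log units; within the scatter) in this assay, a step within the scatter. Compound 3 is therefore estimated at 2000 nM, with a range from 500 nM to 8000 nM.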

Compound 3, half-maximal inhibitory concentration: 2100 nM
Estimate against measurement, compound 3: 1.1-fold (0.02 log units) below; the measured number falls inside the stated range.
By their numbers in this assay, from the lowest: compounds 3 and 2 (each within the scatter of the next); then compound 1.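

In this assay, putting nitro in place of chloro on this aromatic carbon gives a 1.3-fold lower number from compound 2 to compound 3 (0.12 log units; within the scatter), so the two groups cannot be told apart here. Nitro in place of hydrogen gives a 13-fold lower number from compound 1 to compound 3 (1.12 log units; beyond the scatter), which shows that the drop seen with chloro is not confined to chloro: both groups stand clearly apart from hydrogen at this position. Nothing available explains why the two groups give such similar numbers. From the compounds shown here alone, it remains open whether an amine, a carboxylic acid or a methoxy group at this carbon would also stand apart from hydrogen. Going by these compounds, whether chloro or nitro would do the same on another carbon of this ring also remains open.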